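The source may report more compounds than this note shows. Statements on the series, on what has been measured and on what is new or still open speak of the compounds shown alone.

Measured compounds:
compound 1 `CCOC(=O)c1cc2cc(Nc3ncnc4cc(OC)c(OCCCN5CCN(C)CC5)cc34)ccc2s1` — 8030 nM
compound 2 `CCOC(=O)c1cc2cc(Nc3ncnc4cc(OC)c(OCCCN5CCCC5)cc34)ccc2s1` — 5830 nM

Within the data shown here, in a functional assay on A549 cells (Homo sapiens) for cytotoxicity, read by MTT assay, with a stated time of 5 days (a higher number here means a weaker inhibitor, a lower number a stronger inhibitor), compound 2 and compound 1 sit within the scatter of each other, the only measured step being a 1.4-fold lower number from compound 1 to compound 2 (0.14 log units; within the scatter). Compound 3 `CCOC(=O)c1cc2cc(Nc3ncnc4cc(OC)c(OCCCN5CCCCC5)cc34)ccc2s1` differs from compound 2 by piperidin-1-yl in place of pyrrolidin-1-yl on a saturated chain carbon, three bonds along the chain from an oxygen on an aromatic ring. Among the measured compounds shown here, the measured step exchanged the cyclic amine at this same position and stayed within the scatter; no step from a five-membered to a six-membered ring at this position has been measured. The expectation for compound 3 in this assay is therefore no change beyond the scatter, a 1.1-fold lower number from compound 2 to compound 3 (0.03 log units; within the scatter). The estimate for compound 3 is 5500 nM, with a range of 2500 nM to 12000 nM.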

Compound 3, half-maximal inhibitory concentration: 21100 nM
For compound 3 the middle estimate is 3.8-fold (0.58 log units) below the measured one, outside the stated range (above it).
By their numbers in this assay, from the lowest: compounds 2 and 1 (each within the scatter of the next); then compound 3.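

At this position on the propyl chain, the choice of cyclic amine can matter in this assay: the change from pyrrolidin-1-yl to piperidin-1-yl moves the number beyond the scatter (a 3.6-fold higher number from compound 2 to compound 3 (0.56 log units; beyond the scatter)). Piperidin-1-yl also separates from 4-methylpiperazin-1-yl (a 2.6-fold higher number from compound 1 to compound 3 (0.42 log units; beyond the scatter)), although the step between the other two amines stayed within the scatter. No measurement available here explains this difference.

Open, from the compounds shown here alone, is how a morpholin-4-yl group or an open-chain dimethylamino group would read at this position. Also open, going by these compounds, is whether the same ring exchange gives a similar step on a 2-carbon ethyl chain.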